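A few compounds are considered here, and "the series" means these few. Any claim that something is new, unique, unknown or untested is made for them only; others in the source may bear on it.

The measured compounds:
compound 1, `Oc1nc2nonc2nc1Nc1ccc(OCC(F)(F)F)cc1`, 42300 nM
compound 2, `Oc1nc2nonc2nc1Nc1ccc(OCC(F)(F)F)c(F)c1`, 10400 nM
compound 3, `Oc1nc2nonc2nc1Nc1cccc(F)c1`, 31200 nM

These three were tested in an assay on mitochondria from L6 cells (Rattus norvegicus) for activation, with a stated time of 90 min; a higher number here means that more compound is needed for the effect, a lower number that less compound is needed. From compound 1 to compound 2 the change is fluoro in place of hydrogen on an aromatic carbon, and it gave a 4.1-fold lower number from compound 1 to compound 2 (0.61 log units; beyond the scatter). Compound 3 differs from compound 1 in more than one place, so the difference between the two cores is not broken down here; compound 3 shows a 3.0-fold higher number from compound 2 to compound 3 (0.48 log units; beyond the scatter). Compound 4, `Oc1nc2nonc2nc1Nc1cccc(F)c1F`, is not yet measured. It differs from compound 3 by fluoro in place of hydrogen on an aromatic carbon. This is the same kind of change as from compound 1 to compound 2, but the surroundings differ: in compound 2 the fluoro enters ortho to a 2,2,2-trifluoroethoxy group and meta to a large group, whereas in compound 4 it enters ortho to a fluoro group and ortho to a large group. For compound 4 a step of a 2.6-fold lower number from compound 3 to compound 4 (0.41 log units; beyond the scatter) is expected, resting on the earlier result that gave a 4.1-fold lower number from compound 1 to compound 2 (0.61 log units; beyond the scatter), though tempered by the different surroundings. Compound 4 is therefore estimated at 12000 nM, likely between 5000 nM and 30000 nM.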

Compound 4, half-maximal effective concentration: 9700 nM
Compound 4: middle estimate off by 1.2-fold (0.09 log units), on the high side, within the range that was stated.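

In this assay, fluoro in place of hydrogen on an aromatic carbon gave a 3.2-fold lower number from compound 3 to compound 4 (0.51 log units; beyond the scatter) and so moved the number in the same direction as on the earlier core. The two steps agree in size when set side by side: the same change on two cores in this assay, a 4.1-fold lower number (0.61 log units; beyond the scatter) from compound 1 to compound 2 and a 3.2-fold lower number (0.51 log units; beyond the scatter) from compound 3 to compound 4, 1.3-fold (0.10 log units) apart, within the scatter of two such steps.
Among the compounds shown here, this supports carrying the change between these two cores, although it rests on only two pairs of compounds, and it does not show that the step would hold on any other core or at any other place on the ring.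

The compounds shown leave open whether the step would persist on a ring carrying an amine or a carboxylic acid. They also leave open what a longer chain in place of the 2,2,2-trifluoroethoxy group would do.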